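The compounds below may be only part of what the source reports. "The series", "measured", "known", "first", "only" and "open" are said of these compounds alone.

So far, two compounds have numbers in a functional assay on a cell-free system (plasma, Homo sapiens); a higher number here means a weaker inhibitor, a lower number a stronger inhibitor. Compound 1 `CC(C)C[C@H](NC(=O)[C@H](CCCCN)NC(=O)[C@H](CCCN=C(N)N)NC(=O)[C@H](CCCCN)NC(=O)[C@H]1CCCN1)C(=O)N[C@H](C(=O)N1CCC[C@@H]1C(N)=O)C(C)C` gives 2900 nM and compound 2 `CC(C)C[C@H](NC(=O)[C@H](CCCCN)NC(=O)[C@@H]1CCCN1C(=O)[C@@H](N)CCCN=C(N)N)C(=O)N[C@H](C(=O)N1CCC[C@H]1C(=O)O)C(C)C` gives 802 nM. Compound 1 therefore has the higher number of the two and is the weaker inhibitor, and the gap lies beyond the usual scatter of repeated measurements. Compound 3 `CC(C)C[C@H](NC(=O)[C@H](CCCCN)NC(=O)[C@H](CCCN=C(N)N)NC(=O)[C@H](CCCCN)NC(=O)[C@H]1CCCN1)C(=O)N[C@H](C(=O)N1CCC[C@@H]1C(=O)O)C(C)C` is still unmeasured. It differs from compound 1 at one place: on a carbonyl carbon, hydroxy stands in place of amino, so carbamoyl becomes carboxy (hydroxy in place of amino on a carbonyl carbon). Within the data shown here, no measured pair shows this change alone, so the forecast rests on thin evidence. Among the measured compounds shown here, the only guide is that compound 2 reaches 802 nM in this small set. A small move toward a lower number is expected, estimated as a 1.9-fold lower number from compound 1 to compound 3 (0.29 log units; within the scatter) and hardly beyond the scatter. The estimate for compound 3 is 1500 nM, with an expected range from 450 nM to 5000 nM.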

Compound 3, half-maximal inhibitory concentration: 1560 nM
For compound 3 the middle estimate is 1.0-fold (0.02 log units) below the measured one; the measured number falls inside the stated range.
By their numbers in this assay, from the lowest: compounds 2, 3 and 1 (each within the scatter of the next, the first and the last beyond it).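

Among these compounds, the change of carbamoyl to carboxy, with hydroxy in place of amino on a carbonyl carbon, can now be read directly for the first time: in this assay it gives a 1.9-fold lower number from compound 1 to compound 3 (0.27 log units; within the scatter) on an otherwise identical structure. This pair therefore gives no sign that the choice between these two end groups matters at this place, since compound 1 and compound 3 cannot be told apart in this assay. No measurement is available that could explain this result.

Still open, going by these compounds, is whether a methyl ester or a primary alcohol at the same place would also stay within the scatter of compound 3. A single pair also cannot show whether carbamoyl to carboxy would read the same way on a different core.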